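Methylating the amide nitrogen of a very weak amine oxidase A ligand

The compounds below may be only part of what the source reports. "The series", "measured", "known", "first", "only" and "open" are said of these compounds alone.

Compound 1, `c1ccc(CCCCNCc2cc3ccccc3[nH]2)cc1`: 100000000 nM
Compound 2, `O=C(NCCCCc1ccccc1)c1ccc[nH]1`: 55000000 nM

Of the compounds shown here, two have been tested in an assay on isolated protein for inhibition of Amine oxidase [flavin-containing] A (Homo sapiens); a lower number here means a stronger inhibitor, a higher number a weaker inhibitor. In this assay compound 1 gives 100000000 nM and compound 2 gives 55000000 nM. The gap between these two numbers lies within the usual scatter of the measurement, so compound 2 and compound 1 cannot be told apart; both are very weak inhibitors.

Compound 3, `CN(CCCCc1ccccc1)C(=O)c1ccc[nH]1`, has not yet been measured in this assay. It differs from compound 2 in one place: methyl in place of hydrogen on an amide-type nitrogen. Going by the values given here, no step between two measured compounds of this kind is available, so the expectation rests on the structural change alone. A single methyl on the amide nitrogen of a compound this weak is expected to move the number little, with no step beyond the scatter in either direction; the estimated step is a 1.1-fold higher number from compound 2 to compound 3 (0.04 log units; within the scatter). Compound 3 is therefore expected to give about 60000000 nM in this assay, with a plausible range from 20000000 nM to 200000000 nM.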

Compound 3, inhibition constant: 89900000 nM
The estimate for compound 3 lay 1.5-fold (0.18 log units) below the measured number, within the range that was stated.
By their numbers in this assay, from the lowest: compounds 2, 3 and 1 (each within the scatter of the next).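

In this assay, methyl in place of hydrogen on the amide-type nitrogen gives a 1.6-fold higher number from compound 2 to compound 3 (0.21 log units; within the scatter) and so leaves compound 3 indistinguishable from compound 2. Going by these compounds alone, this is the first reading at this position, and it shows that the amide hydrogen can be exchanged for methyl with no change that this measurement can resolve. Within the data shown here, the finding has a narrow reach, however: it rests on one pair of compounds, both very weak inhibitors, and it shows only that this single change does not lift compound 2 out of that very weak range.

The compounds shown leave open whether a larger group on the same nitrogen, such as ethyl or benzyl, would also make no difference, or whether a step beyond the scatter can be seen at this position at all. They also leave open what a longer chain, or an amine or a carboxylic acid on the phenyl ring, would do to the number in this assay. No independent measurement is available that bears on this result or offers a way to interpret it.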